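A few compounds are considered here, and "the series" means these few. Any claim that something is new, unique, unknown or untested is made for them only; others in the source may bear on it.

Three esters built on one shared core, compound 1 `CCCCCCCCCCCCCOC(=O)CCC(=O)N1CCN(CCCOc2cc3c(Nc4ccc(F)c(Cl)c4)ncnc3cc2OC)CC1`, compound 2 `CCCCCCCCCCCCCCOC(=O)CCC(=O)N1CCN(CCCOc2cc3c(Nc4ccc(F)c(Cl)c4)ncnc3cc2OC)CC1` and compound 3 `CCCCCCCCCCCCCCCCCOC(=O)CCC(=O)N1CCN(CCCOc2cc3c(Nc4ccc(F)c(Cl)c4)ncnc3cc2OC)CC1`, differ only in the length of the saturated chain on the oxygen next to the carbonyl group. In a functional assay on A549 cells (Homo sapiens) for cytotoxicity, read by MTT assay, with a stated time of 24 h, tested at 20 uM (a higher number here means a weaker effect of the compound at the concentration tested, a lower number a stronger effect), compound 1 gives 93.8%, compound 2 gives 92.3% and compound 3 gives 97.2%. The steps are small: a number 1.5 percentage points lower from compound 1 to compound 2 (within the scatter), a number 3.4 percentage points higher from compound 1 to compound 3 (within the scatter) and a number 4.9 percentage points higher from compound 2 to compound 3 (within the scatter), so the three compounds cannot be told apart in this assay.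

Compound 4 `CCCCCCCCCCCCCCCCCCOC(=O)CCC(=O)N1CCN(CCCOc2cc3c(Nc4ccc(F)c(Cl)c4)ncnc3cc2OC)CC1` has not yet been measured. The change from compound 1 to compound 2, (methyl in place of hydrogen on a saturated chain carbon, ten or more bonds along the chain from an oxygen next to a carbonyl group), made the step of a number 1.5 percentage points lower from compound 1 to compound 2 (within the scatter). The change from compound 3 to compound 4 is methyl in place of hydrogen on a saturated chain carbon, ten or more bonds along the chain from an oxygen next to a carbonyl group, the same change at the same place. The two cores differ by butyl in place of hydrogen on a saturated chain carbon, ten or more bonds along the chain from an oxygen next to a carbonyl group.

Compound 4 is expected to sit close to compound 3, with a step of about a number 1.2 percentage points lower from compound 3 to compound 4 (within the scatter), because the earlier step of a number 1.5 percentage points lower from compound 1 to compound 2 (within the scatter) stayed within the scatter and compound 3 gives 97.2%. Compound 4 is therefore estimated at 96%, most likely between 88% and 102%.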

Compound 4, a percentage reported as activity, at one concentration (the size of the read-out at that concentration, not a potency): 90.5%
Estimate against measurement, compound 4: 5.5 percentage points above; low and high end bracket the measured number.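

In this assay the methyl change gives a number 6.7 percentage points lower from compound 3 to compound 4 (within the scatter), the butyl change gives a number 1.8 percentage points lower from compound 2 to compound 4 (within the scatter) and the pentyl change gives a number 3.3 percentage points lower from compound 1 to compound 4 (within the scatter), so the four esters cannot be told apart. Set beside its earlier counterpart on another core, the methyl change shows no difference that can be read: the same change on two cores in this assay, a number 1.5 percentage points lower (within the scatter) from compound 1 to compound 2 and a number 6.7 percentage points lower (within the scatter) from compound 3 to compound 4, 5.2 percentage points apart, within the scatter of two such steps. Going by these compounds alone, the butyl change reads the same way, but this shows only that these small steps stay within the scatter at one concentration, not that the change carries a real effect from core to core, since no step here is large enough to test that: the same change on two cores in this assay, a number 3.4 percentage points higher (within the scatter) from compound 1 to compound 3 and a number 1.8 percentage points lower (within the scatter) from compound 2 to compound 4, 5.2 percentage points apart, within the scatter of two such steps.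

All four compounds differ only in the saturated chain on the oxygen next to the carbonyl group, so what the shared core does in this assay is left open. Going by these compounds, whether a short chain such as ethyl, or an amine or a carboxylic acid on the chain, would give a stronger effect also remains open.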